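Carboxyl variants at the carbonyl of the shared core

A few compounds are considered here, and "the series" means these few. Any claim that something is new, unique, unknown or untested is made for them only; others in the source may bear on it.

Compound 1 `COc1c(N2CC[C@@H](CN)C2)c(F)cc2c(=O)c(C(=O)O)cn(Cc3ccc(-c4ccccc4)cc3)c12` carries the free acid, and in an assay on isolated protein for inhibition of DNA topoisomerase 1 (Homo sapiens), with a stated time of 15 min (a lower number here means a stronger inhibitor, a higher number a weaker inhibitor), compound 1 gives 26000 nM. Among the compounds with values here, compound 2 `COc1c(N2CC[C@@H](CN)C2)c(F)cc2c(=O)c(C(N)=O)cn(Cc3ccc(-c4ccccc4)cc3)c12` carries the primary amide; in this assay compound 2 gives 184000 nM, the highest of the two numbers, and the only measured step is a 7.1-fold higher number from compound 1 to compound 2 (0.85 log units; beyond the scatter). Compound 3 `COC(=O)c1cn(Cc2ccc(-c3ccccc3)cc2)c2c(OC)c(N3CC[C@@H](CN)C3)c(F)cc2c1=O` is the methyl ester, with methoxy in place of amino on a carbonyl carbon. Within the data shown here, no measured pair shows this exact change; the one step bears on it only in that it alters the same carbonyl carbon, and it was modest. For compound 3 the expected step is a 1.2-fold lower number from compound 2 to compound 3 (0.09 log units; within the scatter), small and uncertain. Compound 3 is therefore estimated at 150000 nM in this assay, between 40000 nM and 500000 nM.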

Compound 3, half-maximal inhibitory concentration: 71400 nM
Compound 3: the middle estimate sits 2.1-fold (0.32 log units) above what was measured; the range from low to high includes it.
By their numbers in this assay, from the lowest: compound 1; then compound 3; then compound 2.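

In this assay, methoxy in place of amino on the carbonyl carbon gives a 2.6-fold lower number from compound 2 to compound 3 (0.41 log units; beyond the scatter), while methyl in place of hydrogen on the acid oxygen gives a 2.7-fold higher number from compound 1 to compound 3 (0.44 log units; beyond the scatter). The methyl ester therefore falls between the free acid and the primary amide, so this position separates all three groups, and replacing the hydroxy with methoxy costs less than replacing it with amino. No measured evidence accounts for this order. From the compounds shown here alone, whether an ethyl ester or a methylamide at this carbonyl carbon would fit the same order remains open.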